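Compound 4: methoxy in place of fluoro

The compounds below may be only part of what the source reports. "The series", "measured", "known", "first", "only" and "open" are said of these compounds alone.

Series notes. Compound 1 `CCC(c1ccccc1)c1nc(-c2ccc(Cl)cc2)c(CC(=O)O)s1` carries an ethyl group on the carbon joining the two aromatic rings. In an in vitro functional assay on HEK285-7 cells for antagonist activity at prostaglandin D2 receptor 2 (Homo sapiens), read by BRET and beta-arrestin recruitment (a higher number here means a weaker inhibitor, a lower number a stronger inhibitor), compound 1 gives only a limit, > 100000 nM, and no number (the limit of > 100000 nM in this assay, at which 1 of the 3 values shown sits). Compound 2 `O=C(O)Cc1sc(C(c2ccccc2)c2ccc(Cl)cc2)nc1-c1ccc(Cl)cc1` gives 75 nM in this assay, and compound 3 `O=C(O)Cc1sc(C(c2ccccc2)c2ccc(F)cc2)nc1-c1ccc(Cl)cc1` gives 36 nM. The moves an at least 1300-fold lower number from compound 1 to compound 2 (3.12 log units; beyond the scatter) and an at least 2700-fold lower number from compound 1 to compound 3 (3.44 log units; beyond the scatter) are both large; the move a 2.1-fold lower number from compound 2 to compound 3 (0.32 log units; beyond the scatter) is modest. Of the two numbers in hand, compound 3 holds the lower one, with compound 2 the nearest; the third value is a limit.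

Compound 4 `COc1ccc(C(c2ccccc2)c2nc(-c3ccc(Cl)cc3)c(CC(=O)O)s2)cc1` differs from compound 3 by methoxy in place of fluoro on an aromatic carbon. Going by the values given here, the one measured step that bears on this position is a 2.1-fold lower number from compound 2 to compound 3 (0.32 log units; beyond the scatter), a modest change on swapping one substituent for another on that ring. Among the compounds with values here, the steps of an at least 1300-fold lower number from compound 1 to compound 2 (3.12 log units; beyond the scatter) and an at least 2700-fold lower number from compound 1 to compound 3 (3.44 log units; beyond the scatter) concern the presence of the whole aryl group rather than its substituent, and show only that the ring itself carries the potency. A substituent change at this position is therefore expected to shift this assay by a modest amount at most, direction uncertain, with a somewhat higher number judged slightly more likely in view of a 2.1-fold lower number from compound 2 to compound 3 (0.32 log units; beyond the scatter). Compound 4 is expected at 60 nM, between 20 nM and 180 nM. The expected step is a 1.7-fold higher number from compound 3 to compound 4 (0.22 log units; within the scatter).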

Compound 4, half-maximal inhibitory concentration: 76 nM
Beside the measured number, compound 4's estimate is 1.3-fold (0.10 log units) below it; the measured number falls inside the stated range.
By their numbers in this assay, from the lowest: compound 3; then compounds 2 and 4 (each within the scatter of the next). At a limit, above all of these: compound 1.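

In this assay, the 4-methoxyphenyl group gives up the edge held by the 4-fluorophenyl group, a 2.1-fold higher number from compound 3 to compound 4 (0.32 log units; beyond the scatter), and it cannot be told apart from the 4-chlorophenyl group, a 1.0-fold higher number from compound 2 to compound 4 (0.01 log units; within the scatter), so fluoro now stands apart from two other substituents at this place rather than from chloro alone. The position therefore takes methoxy, with its added oxygen and hydrogen-bond acceptor, at no cost relative to chloro, and the margin in favour of fluoro stays modest for both replacements. Compound 1 stands at a limit and not at a number, so an at least 1300-fold lower number from compound 1 to compound 4 (3.11 log units; beyond the scatter) is a bound, and it extends to a third substituted aryl group the large separation from the ethyl group seen earlier.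

Still open, on these data alone, is how the series responds at this place to a plain hydrogen, a hydroxyl, an amine or a trifluoromethyl group, and so whether fluoro is an isolated case or part of a wider trend. Nothing measured among these compounds accounts for the modest edge of fluoro over chloro and methoxy.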